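The source may report more compounds than this note shows. Statements on the series, on what has been measured and on what is new or still open speak of the compounds shown alone.

In a functional assay on L5178Y cells (Mus musculus) for inhibition, read by MTT assay, with a stated time of 24 h (a higher number here means a weaker inhibitor, a lower number a stronger inhibitor), compound 1 (`Oc1ccc([C@@H]2C/C(=N\Nc3ccccc3)c3c(O)cc(O)cc3O2)cc1`) gives >= 11300 nM, a limit and not a number. Compound 2 (`Oc1ccc([C@@H]2C/C(=N\Nc3ccc(Br)cn3)c3c(O)cc(O)cc3O2)cc1`) gives >= 11300 nM, which is also a limit, so it has no numeric standing in the series. Both measured compounds stand at the limit of >= 11300 nM in this assay, at which 2 of the 2 values shown sit.

Compound 3 (`Oc1ccc([C@@H]2C/C(=N\Nc3cnccn3)c3c(O)cc(O)cc3O2)cc1`) has pyrazin-2-yl in place of 5-bromopyridin-2-yl on an amine nitrogen. Within the data shown here, the one measured step that bears on a change at this nitrogen is a step that the two limits leave unreadable from compound 1 to compound 2, and it gives no size to carry over. No step beyond the scatter is therefore expected in this assay, and the estimated move is a number no higher from compound 2 to compound 3 (the limit leaves the size open). A further limit is the expected outcome. The estimate for compound 3 is 11300 nM, with an expected range from 6000 nM to 20000 nM.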

Compound 3, half-maximal inhibitory concentration: >= 11300 nM
Compound 3: no number, only a limit; the forecaster's own chance of this, stated with the estimate: 70%; the middle value lies on the limit itself.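

In this assay, among these compounds, compound 1, compound 2 and compound 3 all carry only a limit and not a number, so no step among them can be read. The compounds shown leave open how strongly any of the three inhibits, and whether the group on the amine nitrogen changes that at all.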